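The source may hold more compounds than are shown below. What is called first, only, known or untested is meant among the compounds shown, and "the series" means these compounds.

Working notes on the series. Going by the values given here, in a functional assay on HL-60 cells (Homo sapiens) for inhibition, read by CCK-8 assay, with a stated time of 48 h (on this read-out higher numbers stand for weaker inhibition and lower numbers for stronger inhibition), compound 1 (`O=S(=O)(NCCNC(=S)Nc1cc(C(F)(F)F)cc(C(F)(F)F)c1)c1ccc(-c2ccccc2O[C@H]2CC[C@@H](O)CC2)s1`) gives 2600 nM and compound 2 (`O=C(Nc1ccc([N+](=O)[O-])cc1)N1CCN(S(=O)(=O)c2sccc2-c2ccccc2Oc2ccc(O)c(O)c2)CC1`) gives 4900 nM with the two values within the scatter of each other, so compound 1 is not separated from the only other measured compound. Compound 3 (`O=[N+]([O-])c1ccc(Oc2ccccc2-c2ccc(S(=O)(=O)NCCNC(=S)Nc3cc(C(F)(F)F)cc(C(F)(F)F)c3)s2)cc1`) has 4-nitrophenyl in place of 4-hydroxycyclohexyl on an oxygen on an aromatic ring and the core of compound 1 is otherwise kept. Among the compounds with values here, no measured pair isolates this change. Compound 2 also has an aromatic ring on such an oxygen and stands at 4900 nM but differs elsewhere too. No step beyond the scatter is therefore expected in this assay and neither direction is favoured. The estimated change is a 1.2-fold higher number from compound 1 to compound 3 (0.06 log units; within the scatter) and is expected to be small. For compound 3 the expected value is 3000 nM with an estimated range from 1000 nM to 9000 nM (estimate only).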

Compound 3, half-maximal inhibitory concentration: 7200 nM
Compound 3: middle estimate off by 2.4-fold (0.38 log units), on the low side; measured number inside the range.
By their numbers in this assay, from the lowest: compounds 1, 2 and 3 (each within the scatter of the next, the first and the last beyond it).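

In this assay, 4-nitrophenyl in place of 4-hydroxycyclohexyl on an oxygen on an aromatic ring gives a 2.8-fold higher number from compound 1 to compound 3 (0.44 log units; beyond the scatter), a modest step and the first in the series that isolates a single place. With the rest of the core of compound 1 kept, this position therefore responds to the change, and the 4-hydroxycyclohexyl group sits on the side of stronger inhibition in this pair. No data on any property of these compounds bear on the step, and no cause can be assigned.

From the compounds shown here alone, this single pair changes the ring type, the hydroxyl and the nitro group together, so their separate contributions remain open. A plain cyclohexyl or a 4-aminophenyl on the same oxygen would be needed to separate these contributions.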